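The compounds below may be only part of what the source reports. "The series", "measured", "known", "first", "only" and "open" are said of these compounds alone.

Measured so far in an assay on HEK293 cells for displacement of a labelled ligand from 5-hydroxytryptamine receptor 7 (Rattus norvegicus), with a stated time of 60 min; a lower number here means a stronger inhibitor, a higher number a weaker inhibitor: compound 1 `c1ccc(Cn2cc(-c3ccccc3)c3c2CCNC3)cc1` gives 220 nM; compound 2 `CC(C)(C)c1ccc(-c2cn(Cc3ccccc3)c3c2CNCC3)cc1` gives 10000 nM; compound 3 `Clc1cccc(-c2cn(Cc3ccccc3)c3c2CNCC3)c1` gives 10000 nM.

Compound 1 stands lowest of the three numbers; the step of a 45-fold higher number from compound 1 to compound 2 (1.66 log units; beyond the scatter) and the step of a 45-fold higher number from compound 1 to compound 3 (1.66 log units; beyond the scatter) both run upward and well beyond the scatter.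

Compound 4 `Clc1cccc(Cn2cc(-c3ccccc3)c3c2CCNC3)c1` differs from compound 1 by chloro in place of hydrogen on an aromatic carbon, on an aromatic carbon of a six-membered aromatic ring of carbon only, meta to a large group. Going by the values given here, the two measured steps concern substitution on the other aromatic ring of the shared core, so they bear only indirectly on this change; no measured pair tests substitution at this place. A loss in this assay of moderate size, a 2.0-fold higher number from compound 1 to compound 4 (0.31 log units; beyond the scatter), is therefore expected rather than a large one. Compound 4 is estimated at 450 nM, with a range of 120 nM to 2500 nM.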

Compound 4, inhibition constant: 6600 nM
Estimate against measurement, compound 4: 15-fold (1.17 log units) below, outside the stated range (above it).
By their numbers in this assay, from the lowest: compound 1; then compounds 4, 2 and 3 (each within the scatter of the next).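

In this assay, chloro in place of hydrogen on this six-membered aromatic ring is no minor change: the result is a 30-fold higher number from compound 1 to compound 4 (1.48 log units; beyond the scatter). Loss on substitution had so far been seen only on the other aromatic ring, and with a 45-fold higher number from compound 1 to compound 3 (1.66 log units; beyond the scatter) on that ring, the phenyl to 3-chlorophenyl change is now costly on both. Nothing measured here explains the loss.

Going by these compounds, whether the loss is specific to chloro or extends to fluoro, methoxy or an amine at this place remains open. Chloro elsewhere on this ring is equally untested in the compounds shown.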